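Removing an Ester Chain: Cytotoxicity Still Expected Low

The source may report more compounds than this note shows. Statements on the series, on what has been measured and on what is new or still open speak of the compounds shown alone.

Compound 1 `CCCCOc1ccc(-c2nc3ncccn3c2NCC2CC2)cc1`: in a toxicity assay on A549 cells (Homo sapiens) for cytotoxicity, read by luminescence and CellTiter-Glo, with a stated time of 48 h (a lower number here means that less compound is tolerated, a higher number that more compound is tolerated), compound 1 gives > 100000 nM, which is a limit of the assay rather than a measured number.
Compound 2 `CCOC(=O)CCCOc1ccc(-c2nc3ncccn3c2NC2CCCCC2)cc1`: in this assay compound 2 gives > 100000 nM, again a limit of the assay, not a number.

Both measured compounds share one core, decorated with different side groups, and neither has shown measurable cytotoxicity. Compound 2 therefore stands at the very edge of what the assay can report: its value is the limit of > 100000 nM in this assay, at which 2 of the 2 values shown sit. Since both values are limits, nothing can be said about any difference between compound 1 and compound 2.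

Compound 3 `c1ccc(-c2nc3ncccn3c2NC2CCCCC2)cc1` is the unmeasured relative of compound 2. It differs from compound 2 in one place: hydrogen in place of 3-(ethoxycarbonyl)propoxy on an aromatic carbon. The compound is thus smaller and plainer, keeping the core and the cyclohexylamino group untouched.

Given that compound 2 sits at the limit (the limit of > 100000 nM in this assay, at which 2 of the 2 values shown sit), compound 3 is expected to show no step beyond the usual scatter in this assay, that is a number no higher from compound 2 to compound 3 (the limit leaves the size open). The estimate for compound 3 is 100000 nM, within 30000 nM to 300000 nM.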

Compound 3, half-maximal cytotoxic concentration: 100000 nM
Estimate against measurement, compound 3: no gap at the digits printed, and the stated range covers the measured number.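

For the compounds shown here, compound 3 gives 100000 nM in this assay, the first actual number rather than a limit of the assay. With the whole 3-(ethoxycarbonyl)propoxy chain gone and plain hydrogen on that aromatic carbon, para to a large group, a very high concentration is still tolerated, so low cytotoxicity here does not depend on carrying this chain. The change reads as a number no higher from compound 2 to compound 3 (the limit leaves the size open) and its size cannot be read, because one end of the step is a limit: the limit of > 100000 nM in this assay, at which 2 of the 3 values shown sit.

The compounds shown leave open how much room this position has, since only the bare hydrogen and two oxygen-linked chains appear on the shared core, and a carboxylic acid at the end of the chain, a primary amine or a small methoxy group could each behave differently. They also leave open whether the cyclohexylamino group plays any part in this tolerance, as a smaller group on that nitrogen has yet to be paired with compound 3 in a change at one place.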